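A few compounds are considered here, and "the series" means these few. Any claim that something is new, unique, unknown or untested is made for them only; others in the source may bear on it.

Compound 1 `CC(=O)SCCC(CCCCC(=O)Nc1cccc(Cl)c1)SC(C)=O` and compound 2 `CC(=O)SCCC(CCCCC(=O)Nc1ccc(Cl)cc1)SC(C)=O` share a core and differ only in the chlorophenyl group on the amide nitrogen, with 4-chlorophenyl in place of 3-chlorophenyl on an amide-type nitrogen. In a functional assay on Bel-7402 cells (Homo sapiens) for inhibition, read by MTT assay, with a stated time of 24 h, tested at 100 ug/mL (on this read-out higher numbers stand for more inhibition of growth at the one concentration tested and lower numbers for less inhibition of growth), compound 1 gives 20.8%, while compound 2 gives 45.5%, so the change brings a number 24.7 percentage points higher from compound 1 to compound 2 (beyond the scatter). Compound 3 `O=C(CCCCC(CCSC(=O)c1ccccc1)SC(=O)c1ccccc1)Nc1cccc(Cl)c1` carries a different core, and the difference between its core and that of compound 1 is not broken down here; in this assay compound 3 is reported as "not active" (no number reported), with no number attached. Compound 4 `O=C(CCCCC(CCSC(=O)c1ccccc1)SC(=O)c1ccccc1)Nc1ccc(Cl)cc1` stands to compound 3 as compound 2 stands to compound 1, the change being (4-chlorophenyl in place of 3-chlorophenyl on an amide-type nitrogen), made at the same place on an amide-type nitrogen whose other neighbour is a carbonyl carbon. Among the compounds with values here, since the only measured instance of this change moved the read-out by a modest amount, and since compound 3 offers no number to build on, the step from compound 3 to compound 4 is expected to be of similar modest size at most, with wide uncertainty. Compound 4 is therefore estimated at 18% in this assay, between 0% and 42%.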

Compound 4, percent growth inhibition at one concentration: "not active" (no number reported)
Nothing numeric was reported for compound 4; there is nothing to compare the estimate with.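

Compound 3 and compound 4 are both reported without a number, so no step can be read between them. Nothing shown here offers an explanation for this result. The compounds shown leave open whether 4-chlorophenyl in place of 3-chlorophenyl changes growth inhibition at all on the core of compound 3.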